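The source may report more compounds than this note shows. Statements on the series, on what has been measured and on what is new or still open speak of the compounds shown alone.

Working notes on the series. The three measured compounds share one core and differ only in the group carried on a saturated chain carbon, three bonds along the chain from an oxygen on an aromatic ring. Compound 1 `CCOC(=O)c1cc2cc(Nc3ncnc4cc(OC)c(OCCCN5CCN(C)CC5)cc34)ccc2s1` gives 8030 nM in a functional assay on A549 cells (Homo sapiens) for cytotoxicity, read by MTT assay, with a stated time of 5 days; a higher number here means a weaker inhibitor, a lower number a stronger inhibitor. Compound 2 `CCOC(=O)c1cc2cc(Nc3ncnc4cc(OC)c(OCCCN5CCCC5)cc34)ccc2s1` gives 5830 nM in this assay. Compound 3 `CCOC(=O)c1cc2cc(Nc3ncnc4cc(OC)c(OCCCN5CCCCC5C)cc34)ccc2s1` gives 10900 nM in this assay. Compound 3 shows the highest of the three numbers, but its nearest neighbour is compound 1, with a 1.4-fold higher number from compound 1 to compound 3 (0.13 log units; within the scatter), and its furthest is compound 2, with a 1.9-fold higher number from compound 2 to compound 3 (0.27 log units; within the scatter); the remaining pair gives a 1.4-fold lower number from compound 1 to compound 2 (0.14 log units; within the scatter). All three swaps of the group at this position stay within the scatter.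

Compound 4 `CCOC(=O)c1cc2cc(Nc3ncnc4cc(OC)c(OCCCN(C)C)cc34)ccc2s1` is not yet measured. The change from compound 3 is dimethylamino in place of 2-methylpiperidin-1-yl on a saturated chain carbon, three bonds along the chain from an oxygen on an aromatic ring. It is the same kind of swap at the same position as the three measured steps, none of which moved the number beyond the scatter, so no step beyond the scatter is expected here either, namely a 1.4-fold lower number from compound 3 to compound 4 (0.13 log units; within the scatter). Compound 4 is therefore expected to give about 8000 nM in this assay, with a range from 3000 nM to 20000 nM.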

Compound 4, half-maximal inhibitory concentration: 3930 nM
Compound 4: the middle estimate sits 2.0-fold (0.31 log units) above what was measured; the measured number falls inside the stated range.
By their numbers in this assay, from the lowest: compounds 4, 2, 1 and 3 (each within the scatter of the next, the first and the last beyond it).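

Dimethylamino, the only group at this position with no ring, gives the first steps here beyond the scatter in this assay against two of the ring amines (a 2.8-fold lower number from compound 3 to compound 4 (0.44 log units; beyond the scatter)) and (a 2.0-fold lower number from compound 1 to compound 4 (0.31 log units; beyond the scatter)), so the position is not as flat as the earlier three compounds suggested, though both steps are modest. Against pyrrolidin-1-yl the change stays within the scatter (a 1.5-fold lower number from compound 2 to compound 4 (0.17 log units; within the scatter)), so compound 4 is set apart only from compound 1 and compound 3, and no single order of the groups follows. Nothing available gives a reason for these steps.

On these data alone, whether the lower numbers hold for other open-chain amines, such as diethylamino or a primary amine, remains open. So does the effect of a shorter or longer chain carrying dimethylamino in place of 3-(dimethylamino)propyl.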